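A few compounds are considered here, and "the series" means these few. Any claim that something is new, unique, unknown or untested is made for them only; others in the source may bear on it.

Measured so far in an ADME assay on HEK293 cells (Homo sapiens) for cytotoxicity, read by MTT assay, with a stated time of 24 h; on this read-out higher numbers stand for weaker inhibition and lower numbers for stronger inhibition:

compound 1 (`COC(=O)c1scc(-c2ccc(NC(=O)c3ccc4ccccc4c3)cc2)c1OC`): "not determined" (no result reported)
compound 2 (`COC(=O)c1scc(-c2ccc(NC(=O)c3ccccn3)cc2)c1OC`): "not determined" (no result reported)
compound 3 (`COC(=O)c1scc(-c2ccc(NC(=O)c3ccc(C(F)(F)F)cc3Br)cc2)c1OC`): > 50000 nM (a limit)

Compound 2 has no number to stand on: its entry reads "not determined" (no result reported) and offers no starting point for a comparison. Compound 1 is in the same position, with an entry of "not determined" (no result reported) in this test. The only result with any content comes from compound 3. Compound 3 reads > 50000 nM in this assay and that is a limit of the assay, not a measured number.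

The next compound to be tested is compound 4 (`COC(=O)c1scc(-c2ccc(NC(=O)c3cccc(I)c3)cc2)c1OC`). The change is 3-iodophenyl in place of pyridin-2-yl on a carbonyl carbon and it puts 3-iodophenyl in place of pyridin-2-yl on a carbonyl carbon, leaving the shared core untouched.

Among the compounds with values here, no measured pair in this small set shows what such a swap does, so the size of the step cannot be read from data. The expectation is therefore modest: no step beyond the usual scatter and no firm direction. It rests on compound 3 with its limit of > 50000 nM in this assay and on nothing firmer. For compound 4 the estimated value in this assay is 50000 nM with an expected range from 20000 nM to 100000 nM and the assay may well report only a limit again.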

Compound 4, half-maximal inhibitory concentration: 42700 nM
For compound 4 the middle estimate is 1.2-fold (0.07 log units) above the measured one; low and high end bracket the measured number.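

No step can be read for compound 4, which carries 3-iodophenyl in place of the pyridin-2-yl of compound 2: compound 2 reads "not determined" (no result reported), so there is no number to compare with. The compounds shown leave open what this swap does in this assay, where one result is still only a limit: the limit of > 50000 nM in this assay, at which 1 of the 4 values shown sits.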